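The source may hold more compounds than are shown below. What is called first, only, known or untested is meant among the compounds shown, and "the series" means these compounds.

Notes on the series in an ADME assay on BJ cells (Homo sapiens) for cytotoxicity, with a stated time of 72 h; a lower number here means that less compound is needed, a higher number that more compound is needed for the effect. Compound 1 (`C=C[C@@](C)(/C=C/c1ccc(O)cc1)CC/C=C/C(=O)OCC`) gives > 36600 nM, a limit of the assay and not a number. Compound 2 (`C=C[C@@](C)(/C=C/c1ccc(O)c(/C=C/c2ccc(Cl)cc2)c1)CCC=C(C)C`) gives > 36600 nM, again a limit. Compound 3 (`CCOc1ccc(/C=C/[C@@](C)(/C=C/c2ccc(O)cc2)CCC=C(C)C)cc1`) gives > 36600 nM, also a limit. The whole set is summed up by the limit of > 36600 nM in this assay, at which 3 of the 3 values shown sit. Compound 3 therefore has no number of its own, and nothing ranks it against the other two.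

Compound 4 (`CC(C)=CCC[C@](C)(/C=C/c1ccc(O)cc1)/C=C/c1cccc(F)c1`) has not been measured yet. It differs from compound 3 by 3-fluorophenyl in place of 4-ethoxyphenyl on a double-bonded chain carbon bound to a double-bonded chain carbon.

Within the data shown here, no pair of measured compounds gives a step to size this change against, and no direction can be read from the data. The expectation in this assay is no step beyond the scatter, and it rests on compound 3 sitting at > 36600 nM along with the other two compounds. The estimated change is a step that the limit leaves unreadable from compound 3 to compound 4. For compound 4 the estimated value is 40000 nM, with an expected range of 15000 nM to 80000 nM.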

Compound 4, half-maximal effective concentration: > 36600 nM
Compound 4 gave a limit, no number; the forecaster's own chance of this, stated with the estimate: 80%; the middle value is on the limit's open side.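

In this assay compound 4 gives > 36600 nM, a limit and not a number. Compound 3 and compound 4 both rest on a limit, so no step between them can be read: the limit of > 36600 nM in this assay, at which 4 of the 4 values shown sit.

The compounds shown leave open what effect, if any, 3-fluorophenyl in place of 4-ethoxyphenyl has on the read-out, and what concentration any of these compounds would need for the effect.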